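The source may report more compounds than this note shows. Statements on the series, on what has been measured and on what is new or still open speak of the compounds shown alone.

Working notes on the shared core of compound 1 `CC(=O)Nc1cccc(NC(=O)COc2ccc3c(=O)ccoc3c2)c1`, which in an assay on isolated protein for inhibition of Rho-associated protein kinase 1 (Homo sapiens), read by scintillation counting, radiometric assay and 33P incorporation, with a stated time of 40 min, in the presence of a further agent that is not named here (a lower number here means a stronger inhibitor, a higher number a weaker inhibitor), gives 2500 nM. Compound 2 `O=C(COc1ccc2c(=O)ccoc2c1)Nc1cccc(NC(=O)c2ccccc2)c1` gives 120 nM in this assay, the change being a 21-fold lower number from compound 1 to compound 2 (1.32 log units; beyond the scatter). Compound 3 `Cn1ccc(S(=O)(=O)Nc2cccc(NC(=O)COc3ccc4c(=O)ccoc4c3)c2)n1` reaches in this assay only a limit of the assay, > 10000 nM. On the numbers shown compound 3 stands at the weak end, with an at least 4.0-fold higher number from compound 1 to compound 3 (0.60 log units; beyond the scatter) and an at least 83-fold higher number from compound 2 to compound 3 (1.92 log units; beyond the scatter), sitting at the limit of > 10000 nM in this assay, at which 1 of the 3 values shown sits. Compound 4 `Nc1ccc(C(=O)Nc2cccc(NC(=O)COc3ccc4c(=O)ccoc4c3)c2)cc1` carries a group of 9 heavy atoms (7 carbon, 1 nitrogen, 1 oxygen; one six-membered aromatic ring of carbon only) in place of a group of 9 heavy atoms (4 carbon, 2 nitrogen, 2 oxygen, 1 sulfur; one five-membered aromatic ring with 2 hetero atoms), on a nitrogen on an aromatic ring. This step largely reverses the large step from compound 2 to compound 3, so a large drop in this assay is expected, back near the level of compound 2 with its 120 nM. Compound 4 is therefore estimated at 150 nM, range 50 nM to 500 nM. That estimate means an expected step of an at least 66-fold lower number from compound 3 to compound 4 (1.82 log units; beyond the scatter).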

Compound 4, half-maximal inhibitory concentration: 802 nM
Compound 4: the middle estimate sits 5.3-fold (0.73 log units) below what was measured; measured number outside the range, above it.
By their numbers in this assay, from the lowest: compound 2; then compound 4; then compound 1. At a limit, above all of these: compound 3.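

With a 6.7-fold higher number from compound 2 to compound 4 (0.82 log units; beyond the scatter) as the cost of the amino group, the gain from phenyl on this carbonyl carbon is only partly kept, and a 3.1-fold lower number from compound 1 to compound 4 (0.49 log units; beyond the scatter) remains for 4-aminophenyl over methyl. On the nitrogen on an aromatic ring, (4-aminophenyl)carbonyl entering for the sulfonyl-bearing group gives an at least 12-fold lower number from compound 3 to compound 4 (1.09 log units; beyond the scatter) as a bound and no more. Compound 3 stands at a limit of the assay: the limit of > 10000 nM in this assay, at which 1 of the 4 values shown sits.

Open, on these data alone, is whether a hydroxyl, a methoxy or a carboxylic acid in place of the amino group would keep the level of compound 2.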